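Butylamino for butoxy: a step behind assay limits

This account rests on a few compounds, and the source may have more. Where it says the series, first, only, none or still open, it means among the compounds named here.

Compound 3 `CCCCOc1nc(N)nc2c1ncn2/C=C1/CC1(CO)CO` carries butoxy on an aromatic carbon of the shared core. In an ADME assay on Akata cells (Homo sapiens) for cytotoxicity, with a stated time of 7 days (a lower number here means that less compound is tolerated, a higher number that more compound is tolerated), compound 3 gives > 20000 nM, which is a limit and not a number. Compound 1 `Nc1nc(OCc2ccccc2)c2ncn(/C=C3/CC3(CO)CO)c2n1`, with benzyloxy in its stead, gives > 20000 nM, also a limit. Compound 2 `CC(C)CNc1nc(N)nc2c1ncn2/C=C1/CC1(CO)CO`, with isobutylamino there, gives > 24000 nM, again a limit. No exact half-maximal cytotoxic concentration is therefore known for any of the three.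

Compound 4 `CCCCNc1nc(N)nc2c1ncn2/C=C1/CC1(CO)CO` differs from compound 3 by a single change, butylamino in place of butoxy on an aromatic carbon.

The closest measured comparison is a step that the two limits leave unreadable from compound 2 to compound 3, where butoxy takes the place of isobutylamino. The other two comparisons, a step that the two limits leave unreadable from compound 1 to compound 2 and a step that the two limits leave unreadable from compound 1 to compound 3, give no size either. For the measured compounds named here, none of these steps therefore offers a measured size to carry over, and no compound here has yet given a number in this assay. A step beyond the usual scatter is not expected, and the expected step is a step that the limit leaves unreadable from compound 3 to compound 4. For compound 4 the estimate is 24000 nM, with an expected range from 10000 nM to 50000 nM, and the result may well be only a limit again.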

Compound 4, half-maximal cytotoxic concentration: > 24000 nM
Compound 4: only a limit was reported (the forecaster's own chance of this, stated with the estimate: 75%); the middle value lies on the limit itself.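

In this assay compound 4 gives > 24000 nM, which is a limit and not a number. For the compounds shown here, no step between compound 4 and compound 1, compound 2 or compound 3 can be read, because all four values are limits, among them this one: the limit of > 24000 nM in this assay, at which 2 of the 4 values shown sit. The compounds shown leave open where the exact half-maximal cytotoxic concentration of each lies, and so whether butylamino in place of butoxy changes it at all.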